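Benzyl halogen changes on a shared spiro-indole series

The source may hold more compounds than are shown below. What is called first, only, known or untested is meant among the compounds shown, and "the series" means these compounds.

Of the compounds shown here, three on the shared core have been measured. Compound 1 `COc1ccc2[nH]c3c(c2c1)CCNC31CCN(Cc2cc(Cl)ccc2[N+](=O)[O-])CC1` carries a 5-chloro-2-nitrophenyl on the saturated chain carbon bound to the ring amine nitrogen; in an assay on FRT cells for positive allosteric modulation of Cystic fibrosis transmembrane conductance regulator variant N1303K (Homo sapiens), in the presence of a further agent that is not named here (a lower number here means that less compound is needed, a higher number that more compound is needed for the effect), compound 1 gives 7100 nM. Compound 2 `COc1ccc2[nH]c3c(c2c1)CCNC31CCN(Cc2cc(F)cc(Cl)c2)CC1`, with a 3-chloro-5-fluorophenyl in that place, gives 2500 nM in this assay. Compound 3 `COc1ccc2[nH]c3c(c2c1)CCNC31CCN(Cc2ccc(Br)c(F)c2)CC1`, with a 4-bromo-3-fluorophenyl, gives 1800 nM in this assay.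

Compound 3 shows the lowest of the three numbers. The step of a 3.9-fold lower number from compound 1 to compound 3 (0.60 log units; beyond the scatter) is beyond the scatter, as is a 2.8-fold lower number from compound 1 to compound 2 (0.45 log units; beyond the scatter), whereas a 1.4-fold lower number from compound 2 to compound 3 (0.14 log units; within the scatter) lies within it; compound 2 and compound 3 are therefore not separable on these numbers.

Compound 4 `COc1ccc2[nH]c3c(c2c1)CCNC31CCN(Cc2ccc(F)c(Cl)c2F)CC1` differs from compound 3 by 3-chloro-2,4-difluorophenyl in place of 4-bromo-3-fluorophenyl on a saturated chain carbon bound to an amine nitrogen in a ring. Among the compounds with values here, the only measured step that stays within the halophenyl variants is a 1.4-fold lower number from compound 2 to compound 3 (0.14 log units; within the scatter), and it is within the scatter; the two larger steps both remove the nitro group, which compound 4 does not carry. The step to compound 4 is therefore expected to stay within the scatter, with no direction assigned, so that a 1.2-fold higher number from compound 3 to compound 4 (0.09 log units; within the scatter) is the expected size. Compound 4 is estimated to give 2200 nM in this assay, with a likely range from 900 nM to 5500 nM.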

Compound 4, half-maximal effective concentration: 4500 nM
Compound 4: middle estimate off by 2.0-fold (0.31 log units), on the low side; the range from low to high includes it.
By their numbers in this assay, from the lowest: compounds 3, 2, 4 and 1 (each within the scatter of the next, the first and the last beyond it).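

Notes on the benzyl position: in this assay, the step of a 2.5-fold higher number from compound 3 to compound 4 (0.40 log units; beyond the scatter) is the first beyond the scatter between two groups that carry halogens only, so this position does not treat all halophenyl groups alike. The other two steps, a 1.8-fold higher number from compound 2 to compound 4 (0.26 log units; within the scatter) and a 1.6-fold lower number from compound 1 to compound 4 (0.20 log units; within the scatter), both lie within the scatter; neither pair can be separated, and the 5-chloro-2-nitrophenyl group no longer stands apart from every halophenyl group on these numbers. No available evidence bears on the reason for these differences.

The change from 4-bromo-3-fluorophenyl to 3-chloro-2,4-difluorophenyl replaces bromine with chlorine, adds a fluorine and moves the halogens all at once, so the contribution of each part remains unresolved. Also open, as far as these compounds go, is how this position would respond to a group of another kind, such as a nitrile or a methoxy group on the phenyl ring, a pyridine ring in place of the phenyl, or a longer chain to the ring amine nitrogen.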